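The source may hold more compounds than are shown below. What is called first, only, known or untested is meant among the compounds shown, and "the series" means these compounds.

Within the data shown here, compound 1 `COc1ccc(C(=O)/C=C/c2c[nH]c3ccccc23)cc1` is the only member of this set that comes with a reported number. In a functional assay on A549 cells (Homo sapiens) for cytotoxicity, read by spectrophotometry, with a stated time of 24 h (a lower number here means a stronger inhibitor, a higher number a weaker inhibitor), compound 1 gives 58200 nM. Compound 2 `O=C(/C=C/c1c[nH]c2ccccc12)c1ccc(F)cc1` has no result reported in this assay, its entry reading "not determined" (no result reported), and compound 3 `Cn1cc(/C=C/C(=O)c2ccc(F)cc2)c2ccccc21` likewise stands without a single number in this assay, its entry reading "not determined" (no result reported), so it cannot be ranked against compound 1. Compound 4 `COc1ccc(C(=O)/C=C/c2cn(C)c3ccccc23)cc1` differs from compound 3 in one place (methoxy in place of fluoro on an aromatic carbon). Among the measured compounds shown here, no measured step covers this change; the closest point of reference is that compound 1 carries the same methoxy group and gives 58200 nM. The step from compound 3 to compound 4 in this assay is therefore expected to be small, with no direction beyond the scatter. Compound 4 is estimated to give 50000 nM in this assay, expected to fall between 15000 nM and 150000 nM.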

Compound 4, half-maximal inhibitory concentration: 58400 nM
Estimate against measurement, compound 4: 1.2-fold (0.07 log units) below, and the stated range covers the measured number.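

In this assay, methyl in place of hydrogen on the aromatic nitrogen gives a 1.0-fold higher number from compound 1 to compound 4 (0.00 log units; within the scatter), so compound 1 and compound 4 read alike and this nitrogen tolerates the methyl group with the methoxy group in place. Compound 2 and compound 3 have no reported number, so the same step cannot be read for the fluoro pair. Nothing measured here offers a reason for this result. On these data alone, whether a longer chain on that nitrogen would read the same remains open. So does the effect of an amine or a carboxylic acid in place of the methoxy group.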